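Swapping a fused heteroaromatic ring for naphthalene

The source may report more compounds than this note shows. Statements on the series, on what has been measured and on what is new or still open speak of the compounds shown alone.

Compound 1 `CC/C(=C(/c1ccc(/C=C/C(=O)O)cc1)c1ccc2cncn2c1)c1ccccc1` was tested in a functional assay on MCF7 cells (Homo sapiens) for antiproliferative activity, read by CellTiter-Glo, with a stated time of 5 days (on this read-out higher numbers stand for weaker inhibition and lower numbers for stronger inhibition), where compound 1 reached only the limit of the assay, > 500 nM, so its potency is known merely as a limit and not as a number. Compound 2 `CC/C(=C(/c1ccc(/C=C/C(=O)O)cc1)c1ccn2nncc2c1)c1ccccc1` was tested in the same way. In this assay compound 2 likewise gave only the limit > 500 nM. For the measured compounds named here, the single measured step, a step that the two limits leave unreadable from compound 1 to compound 2, therefore cannot be read, because of the limit of > 500 nM in this assay, at which 2 of the 2 values shown sit. Compound 3 `CC/C(=C(/c1ccc(/C=C/C(=O)O)cc1)c1ccc2ccccc2c1)c1ccccc1` is the untested partner of compound 1, and the change is a group of 10 heavy atoms (10 carbon; 2 six-membered aromatic rings of carbon only) in place of a group of 9 heavy atoms (7 carbon, 2 nitrogen; one five-membered aromatic ring with 2 hetero atoms, one six-membered aromatic ring with 1 hetero atom), on a double-bonded chain carbon bound to an aromatic carbon and a double-bonded chain carbon. Going by the values given here, no measured step bears on this change, so the expected size of a number no higher from compound 1 to compound 3 (the limit leaves the size open) in this assay rests on no more than the two limits, and it is estimated to lie around zero with wide uncertainty. Compound 3 is therefore expected to give about 500 nM in this assay, with an estimated range from 100 nM to 2500 nM, and a fair chance that only a limit is again reported.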

Compound 3, half-maximal inhibitory concentration: 180 nM
Estimate against measurement, compound 3: 2.8-fold (0.44 log units) above, within the range that was stated.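

In this assay, this place on a double-bonded chain carbon now gives a measured number rather than a limit, so the shared core can show inhibition in this read-out once it carries naphthalen-2-yl. Putting naphthalen-2-yl, with its 2 six-membered aromatic rings of carbon only, in place of either nitrogen-containing fused group gives an at least 2.7-fold lower number from compound 1 to compound 3 (0.44 log units; beyond the scatter) and an at least 2.7-fold lower number from compound 2 to compound 3 (0.44 log units; beyond the scatter). Both steps are minimum sizes and the full gain stays unknown, because neither nitrogen-containing compound has a number of its own: the limit of > 500 nM in this assay, at which 2 of the 3 values shown sit.

The compounds shown leave open whether the gain depends on having no nitrogen in the fused rings, since a quinolinyl group would test that with a ring pair closer to naphthalen-2-yl, and they also leave open whether a plain phenyl group at this place would do as well. The step from compound 1 to compound 2 cannot be read, so nothing separates the two nitrogen-containing groups from each other.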